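Methylselanyl to methylsulfanyl on a bis-acyl isothiourea core

A few compounds are considered here, and "the series" means these few. Any claim that something is new, unique, unknown or untested is made for them only; others in the source may bear on it.

Compound 1, `C[Se]/C(=N\C(=O)c1ccco1)NC(=O)c1ccco1`, gives 5940 nM in an ADME assay on MCF-10A cells (Homo sapiens) for cytotoxicity, read by MTT assay, with a stated time of 72 h; a lower number here means a stronger inhibitor of growth, a higher number a weaker inhibitor of growth.
Compound 2, `CS/C(=N\C(=O)c1ccco1)NC(=O)c1ccco1`, gives 8220 nM in this assay.
Compound 3, `C[Se]/C(=N\C(=O)c1cnc2ccccc2c1)NC(=O)c1cnc2ccccc2c1`, gives 20300 nM in this assay.

Compound 1 and compound 2 share a core and differ only at one place: a group of 2 heavy atoms (1 carbon, 1 sulfur; no ring) in place of a group of 2 heavy atoms (1 carbon, 1 selenium; no ring), on a carbon with a double bond to nitrogen. This change gave a 1.4-fold higher number from compound 1 to compound 2 (0.14 log units; within the scatter), so the two values cannot be ordered against each other.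

Compound 3 carries a different core, and how the core of compound 3 differs from the core of compound 1 is not broken down here. Compound 3 gives the highest of the three numbers in this assay, beyond the scatter from both compound 1 and compound 2.

Compound 4, `CS/C(=N\C(=O)c1cnc2ccccc2c1)NC(=O)c1cnc2ccccc2c1`, has not yet been measured. It stands to compound 3 exactly as compound 2 stands to compound 1: a group of 2 heavy atoms (1 carbon, 1 sulfur; no ring) in place of a group of 2 heavy atoms (1 carbon, 1 selenium; no ring), on a carbon with a double bond to nitrogen. Because the same change gave a 1.4-fold higher number from compound 1 to compound 2 (0.14 log units; within the scatter), compound 4 is expected to sit close to compound 3 in this assay, with an expected step of a 1.3-fold higher number from compound 3 to compound 4 (0.12 log units; within the scatter). Compound 4 is therefore estimated at 27000 nM, most likely between 12000 nM and 60000 nM.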

Compound 4, concentration for 50% growth inhibition: 500 nM
Estimate against measurement, compound 4: 54-fold (1.73 log units) above; the whole stated range lies above it.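

Replacing the selenium-bearing group with methylsulfanyl, on a carbon with a double bond to nitrogen, gave a 41-fold lower number from compound 3 to compound 4 (1.61 log units; beyond the scatter) in this assay, so the change does not carry over from one core to the other with the same size, as the two steps set side by side show: the same change on two cores in this assay, a 1.4-fold higher number (0.14 log units; within the scatter) from compound 1 to compound 2 and a 41-fold lower number (1.61 log units; beyond the scatter) from compound 3 to compound 4, 56-fold (1.75 log units) apart, beyond the scatter of two such steps
Within this series, then, a step read on one core gave no reliable guide to the same step on the other, and the size of this exchange has to be read core by core. Among these compounds, with only two pairs, this does not show why the cores part ways, nor how the same change would behave on any third core.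

The compounds shown leave open whether a longer chain or an amine in place of methylsulfanyl, at that same carbon, would also respond differently on the two cores. They also leave open whether the large step seen in this assay would appear in cells of another type.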